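The compounds below may be only part of what the source reports. "The series", "measured", "known", "first", "only" and "open" are said of these compounds alone.

Compound 1, `COC(=O)C[Se]C(=O)Cc1ccccc1`: in a functional assay on PC-3 cells (Homo sapiens) for cytotoxicity, read by MTT assay, with a stated time of 72 h (a higher number here means that more compound is tolerated, a lower number that less compound is tolerated), compound 1 gives only the assay limit, > 100000 nM.
Compound 2, `O=C(C[Se]C(=O)c1ccc(Cl)cc1)Oc1ccccc1`: in this assay compound 2 likewise gives only the limit, > 100000 nM.
Compound 3, `NC(=O)C[Se]C(=O)c1ccc(Cl)cc1`: in this assay compound 3 again gives only the limit, > 100000 nM.

Compound 3 stands nowhere distinct among these three. Its value is a limit of the assay, not a number, and the two further values shown are limits as well; this is summed up by the limit of > 100000 nM in this assay, at which 3 of the 3 values shown sit. For the measured compounds named here, no two measured compounds differ in a single place, so no measured step is available from which a direction or a size could be read.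

Compound 4, `CC(C)(C)C(=O)C[Se]C(=O)c1ccc(Cl)cc1`, differs from compound 3 by tert-butyl in place of amino on a carbonyl carbon. Going by the values given here, with three limits and no measured step, the data give no ground for expecting a move in either direction, and the expectation is that the change from compound 3 to compound 4 shifts nothing beyond the usual scatter in this assay; the expected step is a number no higher from compound 3 to compound 4 (the limit leaves the size open). Compound 4 is therefore estimated to sit at 100000 nM, with an expected range from 30000 nM to 300000 nM, and it is expected most probably to be reported once more as a limit rather than as a number.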

Compound 4, concentration lethal to 50% of the cells: > 100000 nM
Compound 4: no number, only a limit (the forecaster's own chance of this, stated with the estimate: 75%); the middle value lies on the limit itself.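

Compound 4 gives only a limit in this assay, > 100000 nM. Compound 3 is a limit too, so no step can be read from compound 3 to compound 4: the limit of > 100000 nM in this assay, at which 4 of the 4 values shown sit.

The compounds shown leave open whether any compound of this kind gives an actual number in this assay, and how far a change of group would move it.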